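The source may hold more compounds than are shown below. What is called first, only, known or untested is meant among the compounds shown, and "the series" means these compounds.

Measured so far:
compound 1 `Cc1ccc(NCc2cn(-c3ccc(C(=O)O)cc3)nc2-c2ccccc2)cc1Cl`: 20 ug/mL
compound 2 `Cc1cc(NCc2cn(-c3ccc(C(=O)O)cc3)nc2-c2ccccc2)ccc1Br`: 17.9 ug/mL

Both numbers come from an ADME assay on HEK293 cells (Homo sapiens) for cytotoxicity (a higher number here means that more compound is tolerated, a lower number that less compound is tolerated), which reports how much of a compound the cells tolerate. Compound 2 `Cc1cc(NCc2cn(-c3ccc(C(=O)O)cc3)nc2-c2ccccc2)ccc1Br` has one neighbour on this scale, compound 1, and the step of a 1.1-fold lower number from compound 1 to compound 2 (0.05 log units; within the scatter) is too small to count as a real difference, so the two sit side by side. Compound 3 `O=C(O)c1ccc(-n2cc(CNc3ccc(F)c(C(F)(F)F)c3)c(-c3ccccc3)n2)cc1` carries a different group on the amine nitrogen: 4-fluoro-3-(trifluoromethyl)phenyl in place of 4-bromo-3-methylphenyl on an amine nitrogen. Within the data shown here, the only step so far, from compound 1 to compound 2, also swapped one substituted phenyl on that nitrogen for another, and it moved the number by no more than the usual scatter. That is thin evidence, and it points to no shift beyond the scatter for compound 3 either. Compound 3 is therefore expected at 17 ug/mL, between 9 ug/mL and 34 ug/mL, a change of a 1.1-fold lower number from compound 2 to compound 3 (0.02 log units; within the scatter) from compound 2.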

Compound 3, half-maximal cytotoxic concentration: > 32 ug/mL
Compound 3: no number, only a limit; the forecaster's own chance of this, stated with the estimate: 10%; at least 1.8-fold (0.27 log units) between middle value and limit.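

In this assay compound 3 gives no number but only a limit: the limit of > 32 ug/mL in this assay, at which 1 of the 3 values shown sits.

The change to 4-fluoro-3-(trifluoromethyl)phenyl on the amine nitrogen gives an at least 1.7-fold higher number from compound 2 to compound 3 (0.25 log units; that floor lies within the scatter), and likewise an at least 1.6-fold higher number from compound 1 to compound 3 (0.20 log units; that floor lies within the scatter). The swap between compound 1 and compound 2 stayed within the scatter, and while these floors alone show no real difference either, this new group brings no sign of lower tolerance and leaves room for a true gap of unknown size.

On these data alone, how large that gap is remains open, as does whether the fluorine or the trifluoromethyl group accounts for any of it. The compounds shown also give no reading for a different kind of group on that nitrogen, such as an unsubstituted phenyl or a longer saturated chain.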